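Working notes: aryl change on the thiocarbonyl piperazine series

A few compounds are considered here, and "the series" means these few. Any claim that something is new, unique, unknown or untested is made for them only; others in the source may bear on it.

Compound 1 `Nc1nc(N)c2cc(CSC(=S)N3CCN(c4ccccc4)CC3)ccc2n1`: 2970 nM
Compound 2 `Nc1nc(N)c2cc(CSC(=S)N3CCN(c4ccc(Cl)cc4)CC3)ccc2n1`: 5210 nM

Within the data shown here, in a functional assay on A549 cells (Homo sapiens) for antiproliferative activity, read by MTT assay, with a stated time of 72 h (on this read-out higher numbers stand for weaker inhibition and lower numbers for stronger inhibition), compound 2 stands within the scatter of compound 1, the only other compound measured, so the two cannot be ranked. Compound 3 `Nc1nc(N)c2cc(CSC(=S)N3CCN(c4ccc(F)cc4F)CC3)ccc2n1` is still unmeasured. It carries 2,4-difluorophenyl in place of 4-chlorophenyl on an amine nitrogen in a ring.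

Among the measured compounds shown here, only one measured step bears on this change, the one placing chloro in place of hydrogen on an aromatic carbon of the same group: a 1.8-fold higher number from compound 1 to compound 2 (0.24 log units; within the scatter). That is a single step, and it stayed within the scatter. The data hold no measured compound with fluorine on this group, so nothing shown points firmly in either direction. No step beyond the scatter is therefore expected in this assay, and any drift is expected to be small.

The estimated step is a 1.4-fold lower number from compound 2 to compound 3 (0.14 log units; within the scatter). For compound 3 the expected value is 3800 nM, with an estimated range of 1700 nM to 8500 nM.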

Compound 3, half-maximal inhibitory concentration: 5120 nM
Estimate against measurement, compound 3: 1.3-fold (0.13 log units) below; low and high end bracket the measured number.
By their numbers in this assay, from the lowest: compounds 1, 3 and 2 (each within the scatter of the next).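

In this assay, 2,4-difluorophenyl in place of 4-chlorophenyl on the amine nitrogen in the ring gives a 1.0-fold lower number from compound 2 to compound 3 (0.01 log units; within the scatter), and 2,4-difluorophenyl in place of phenyl gives a 1.7-fold higher number from compound 1 to compound 3 (0.24 log units; within the scatter). Fluorine now stands on this group for the first time, and with the earlier chloro step, all three pairs among phenyl, 4-chlorophenyl and 2,4-difluorophenyl lie within the scatter, so this position has not separated compound 1, compound 2 and compound 3, whether the aromatic ring carries no halogen, one chlorine or two fluorines. Nothing available here accounts for this flat result.

All three compounds keep a phenyl ring on this nitrogen, which leaves open whether a methoxy group or an amine on that ring, or a benzyl group in its place, would give a step beyond the scatter. Also open is whether a change away from this group, such as a carbonyl in place of the thiocarbonyl, would move the number further than any aryl change shown so far.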